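The compounds below may be only part of what the source reports. "The series", "measured", "known", "first", "only" and "open" are said of these compounds alone.

Working notes on the series. For the measured compounds named here, in an assay on HEK293 cells for binding affinity to 5-hydroxytryptamine receptor 7 (Homo sapiens), read by radioligand binding (a higher number here means a weaker inhibitor, a lower number a stronger inhibitor), compound 3 `CC(C)N1CCCN(CCn2ccc3ccc(Br)cc32)CC1` gives 14 nM, the lowest of the three numbers so far. Compound 1 `CN1CCCN(CCn2ccc3ccc(Br)cc32)CC1` gives 31 nM in this assay, and compound 2 `C#Cc1ccc2ccn(CCN3CCCN(C)CC3)c2c1` gives 140 nM. Two single-point steps connect these: a 4.5-fold higher number from compound 1 to compound 2 (0.65 log units; beyond the scatter) when ethynyl replaces bromo on an aromatic carbon, and a 2.2-fold lower number from compound 1 to compound 3 (0.35 log units; beyond the scatter) when isopropyl replaces methyl on the amine nitrogen in the seven-membered ring. The aromatic change is the larger of the two; the amine change is modest and favourable.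

Compound 4 `CC(C)CN1CCCN(CCn2ccc3ccc(Br)cc32)CC1` is the next member: isobutyl in place of isopropyl on an amine nitrogen in a ring. Going by the values given here, only the step from compound 1 to compound 3 bears on this change, since it too alters the group on the same ring nitrogen, and there the larger group gave the lower number. Whether a further one-carbon extension continues that direction or levels off cannot be told from one step, so the expectation is cautious. For compound 4 an essentially unchanged or slightly lower number is expected in this assay, a 1.3-fold lower number from compound 3 to compound 4 (0.10 log units; within the scatter), because a 2.2-fold lower number from compound 1 to compound 3 (0.35 log units; beyond the scatter) was itself only modest. Compound 4 is therefore estimated at 11 nM, with a range of 4 nM to 30 nM.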

Compound 4, inhibition constant: 37 nM
Compound 4: middle estimate off by 3.4-fold (0.53 log units), on the low side; the measured number lies above the stated range.
By their numbers in this assay, from the lowest: compound 3; then compounds 1 and 4 (each within the scatter of the next); then compound 2.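

In this assay, the group on this ring nitrogen shows no steady trend with size: isobutyl, with 4 heavy atoms against 3 for isopropyl, gives a 2.6-fold higher number from compound 3 to compound 4 (0.42 log units; beyond the scatter), which runs opposite to a 2.2-fold lower number from compound 1 to compound 3 (0.35 log units; beyond the scatter). Compared with the methyl group of compound 1, the isobutyl group amounts to isopropyl in place of hydrogen on the saturated chain carbon bound to the amine nitrogen, giving a 1.2-fold higher number from compound 1 to compound 4 (0.08 log units; within the scatter), so the gain seen with compound 3 is not kept and, among compounds 1, 3 and 4, only compound 3 stands apart from the others. Nothing at hand gives a reason for this reversal.

With only methyl, isopropyl and isobutyl on this nitrogen, the compounds shown leave open whether the result follows from branching, from chain length or from both, and ethyl, n-propyl and cyclopropyl groups there would help separate these readings. On these data alone, it also remains open whether the same order of groups on the ring nitrogen would hold with ethynyl in place of bromo on the aromatic carbon.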